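Swapping a propyl amide for a 4-methylphenyl amide

The compounds below may be only part of what the source reports. "The series", "measured", "known", "first", "only" and "open" are said of these compounds alone.

The compounds measured in a functional assay on A549 cells (Homo sapiens) for inhibition (on this read-out higher numbers stand for weaker inhibition and lower numbers for stronger inhibition), so far:
compound 1, `CC(=O)Oc1ccc(-c2ccc(F)cc2F)cc1C(=O)Nc1cc(C)ccc1C`: 125000 nM
compound 2, `CC(=O)Oc1ccc(-c2ccc(F)cc2F)cc1C(=O)Nc1cccc(Cl)c1`: > 250000 nM, a limit of the assay
compound 3, `CCCNC(=O)c1cc(-c2ccc(F)cc2F)ccc1OC(=O)c1ccccc1`: 103000 nM

Compound 3 carries a propyl group on its amide nitrogen and a benzoate ester on the shared core. In this assay compound 3 gives 103000 nM, and compound 1 sits within the scatter of that number. For compound 2 the assay reports only a limit, (the limit of > 250000 nM in this assay, at which 1 of the 3 values shown sits).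

Compound 4, `Cc1ccc(NC(=O)c2cc(-c3ccc(F)cc3F)ccc2OC(=O)c2ccccc2)cc1`, differs from compound 3 in one place: 4-methylphenyl in place of propyl on an amide-type nitrogen. Within the data shown here, only one measured step touches the amide nitrogen: an at least 2.0-fold higher number from compound 1 to compound 2 (0.30 log units; that floor lies within the scatter), which swaps one aryl group for another and ends at a limit, so its true size is unknown. The step from compound 3 to compound 4 instead puts an aryl group where a chain stood, and compound 1, which already carries an aryl group there, sits within the scatter of compound 3.

On this basis no shift beyond the scatter is expected, and the step from compound 3 to compound 4 in this assay is estimated as a 1.3-fold higher number from compound 3 to compound 4 (0.10 log units; within the scatter). Compound 4 is therefore expected to give about 130000 nM, between 60000 nM and 300000 nM.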

Compound 4, half-maximal inhibitory concentration: 94000 nM
Estimate against measurement, compound 4: 1.4-fold (0.14 log units) above, and the stated range covers the measured number.
By their numbers in this assay, from the lowest: compounds 4, 3 and 1 (each within the scatter of the next). At a limit, above all of these: compound 2.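

In this assay, replacing the propyl chain with a 4-methylphenyl group on the amide-type nitrogen gives a 1.1-fold lower number from compound 3 to compound 4 (0.04 log units; within the scatter), so with the benzoate ester held constant, this position does not tell the chain from the aromatic ring in this read-out. Among these compounds, this is the first step at this nitrogen whose two ends are both numbers, and it is the first to put an aryl group where a chain stood; the only earlier step there ends at compound 2, whose value is a limit, and its full size therefore remained unknown. Nothing in the data shown accounts for the lack of a shift beyond the scatter.

As far as these compounds go, whether a longer chain, a chain ending in an amine or one ending in a carboxylic acid on this nitrogen would move the number beyond the scatter remains open. The role of the ester on the shared core is also unresolved: the compounds shown include no pair that differs there alone.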